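Notes on the carbamoyl-pyrazolyl replacement in the series

The source may report more compounds than this note shows. Statements on the series, on what has been measured and on what is new or still open speak of the compounds shown alone.

Of the compounds shown here, three have been measured in a physicochemical assay for solubility, read by LC-MS, in phosphate buffer, with a stated time of 24 h, at pH 7.4; on this read-out higher numbers stand for higher solubility and lower numbers for lower solubility. Compound 1 `CN(c1ccn(C)n1)c1cnc(NCc2c(F)ccc3c2CCO3)c2cn[nH]c(=O)c12` gives 12000 nM, the highest of the three numbers. Compound 2 `Cc1nccn1-c1cnc(NCc2c(F)ccc3c2CCO3)c2cn[nH]c(=O)c12` gives 7000 nM in this assay, and the step of a 1.7-fold lower number from compound 1 to compound 2 (0.23 log units; within the scatter) is within the scatter, so the two are not ranked. Compound 3 `CN(C)C(=O)c1cc(-c2cnc(NCc3c(F)ccc4c3CCO4)c3cn[nH]c(=O)c23)n(C)n1` gives 3000 nM in this assay, and the step of a 4.0-fold lower number from compound 1 to compound 3 (0.60 log units; beyond the scatter) is beyond the scatter, as is a 2.3-fold lower number from compound 2 to compound 3 (0.37 log units; beyond the scatter).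

Compound 4 `CNC(=O)c1cc(-c2cnc(NCc3c(F)ccc4c3CCO4)c3cn[nH]c(=O)c23)n(C)n1` has not yet been measured. It differs from compound 1 in one place: 1-methyl-3-(methylcarbamoyl)-1H-pyrazol-5-yl in place of methyl(1-methyl-1H-pyrazol-3-yl)amino on an aromatic carbon. Going by the values given here, this change is close to the one from compound 1 to compound 3, where a dimethylcarbamoyl group rather than a methylcarbamoyl group sits on the pyrazolyl ring; there is no measured pair that separates those two amides. The step of a 4.0-fold lower number from compound 1 to compound 3 (0.60 log units; beyond the scatter) is therefore the most direct guide, and a step of similar size and in the same direction, a lower number, is expected in this assay for compound 4.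

Compound 4 is expected to give 3000 nM in this assay, with a range from 1000 nM to 9000 nM. The expected step is a 4.0-fold lower number from compound 1 to compound 4 (0.60 log units; beyond the scatter).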

Compound 4, solubility: 7000 nM
The estimate for compound 4 lay 2.3-fold (0.37 log units) below the measured number; low and high end bracket the measured number.
By their numbers in this assay, from the lowest: compound 3; then compounds 2, 4 and 1 (each within the scatter of the next).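

Notes on the amide nitrogen

In this assay, going by these compounds alone, compound 4 and compound 3 are the first measured pair to separate the two amides: hydrogen in place of methyl on the amide-type nitrogen gives a 2.3-fold higher number from compound 3 to compound 4 (0.37 log units; beyond the scatter). The step away from methyl(1-methyl-1H-pyrazol-3-yl)amino on this aromatic carbon therefore depends on the amide: 1-methyl-3-(methylcarbamoyl)-1H-pyrazol-5-yl gives a 1.7-fold lower number from compound 1 to compound 4 (0.23 log units; within the scatter), whereas 3-(dimethylcarbamoyl)-1-methyl-1H-pyrazol-5-yl gave a 4.0-fold lower number from compound 1 to compound 3 (0.60 log units; beyond the scatter). Against 2-methyl-1H-imidazol-1-yl, the methylcarbamoyl group gives no change at the digits printed from compound 2 to compound 4 (within the scatter), so compounds 1, 2 and 4 cannot be ranked on this read-out, and of the four compounds only compound 3 stands apart from compound 4.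

Nothing at hand accounts for the difference between the two amides. Also open, from the compounds shown here alone, is how a primary carboxamide, a carboxylic acid or an amide carrying a longer chain on its nitrogen, each in place of the methylcarbamoyl group, would read in this assay, and whether the gap between the two amides would hold on any other ring.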